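The compounds below may be only part of what the source reports. "The series", "measured", "known", "first", "only" and "open" are said of these compounds alone.

Compound 1 `NC(=O)CCNC(=O)c1cccc(S)c1`: > 100 uM
Compound 2 `CCCC(=O)OCSc1ccccc1C(=O)NCC(N)=O`: > 100 uM

In an ADME assay on CEM-SS cells (Homo sapiens) for cytotoxicity, read by XTT assay, with a stated time of 6 days (on this read-out higher numbers stand for lower toxicity in this test and lower numbers for higher toxicity in this test), compound 2 gives > 100 uM, and this is a limit of the assay, not a number. Compound 1 gives > 100 uM, also a limit. Among the measured compounds shown here, the series so far comes down to a single observation: the limit of > 100 uM in this assay, at which 2 of the 2 values shown sit. For the measured compounds named here, no step between measured compounds can be read from these results.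

Compound 3 `CCCC(=O)OCSc1ccccc1C(=O)NCCCCCCNC(C)=O` is the next entry. It has 5-acetamidopentyl in place of carbamoyl on a saturated chain carbon bound to an amide-type nitrogen.

No step beyond the usual scatter is expected in this assay, and a report at the limit is the most likely outcome. The expectation rests on compound 2, whose value of > 100 uM is a limit. That limit does not show how much room lies under it, so the estimated range extends further toward lower numbers, meaning higher toxicity in this test. The expected change is a number no higher from compound 2 to compound 3 (the limit leaves the size open). For compound 3 the estimated value is 100 uM, with an expected range of 40 uM to 200 uM.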

Compound 3, half-maximal toxic concentration: 8 uM
The estimate for compound 3 lay 13-fold (1.10 log units) above the measured number, outside the stated range (below it).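

In this assay, 5-acetamidopentyl in place of carbamoyl on a saturated chain carbon bound to an amide-type nitrogen gives an at least 12-fold lower number from compound 2 to compound 3 (1.09 log units; beyond the scatter), which shows that this position can change the read-out, towards higher toxicity in this test. The group that enters has 9 heavy atoms against 3 in the group that leaves, while the counts of hydrogen-bond donors and acceptors stay the same and neither group brings a ring or a net charge, so the step goes with a larger, chain-bearing group and not with any change in those counts. Compound 3 is also the first entry to give a number instead of a limit, whereas the series had until now offered a single observation: the limit of > 100 uM in this assay, at which 2 of the 3 values shown sit.

The compounds shown do not separate the contribution of the pentyl chain from that of its terminal acetamide, and a plain pentyl chain, a shorter chain or a chain ending in a free amine would each bear on that question. From the compounds shown here alone, how the toxicity in this test varies with chain length also remains open, as a single step gives no trend.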